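Methoxy in place of trifluoromethyl on the biphenyl end

A few compounds are considered here, and "the series" means these few. Any claim that something is new, unique, unknown or untested is made for them only; others in the source may bear on it.

Compound 1 `COc1ccc(-c2ccc(N(C[C@@H](N)CC(C)C)C(=O)[C@@H]3C[C@H]3c3ccccc3)cc2)cc1`: 330 nM
Compound 2 `CCCc1ccc(-c2ccc(N(C[C@@H](N)[C@@H](C)CC)C(=O)[C@@H]3C[C@H]3c3ccccc3)cc2)cc1`: 61 nM
Compound 3 `CC[C@H](C)[C@H](N)CN(C(=O)[C@@H]1C[C@H]1c1ccccc1)c1ccc(-c2ccc(C(F)(F)F)cc2)cc1`: 340 nM

Of the compounds shown here, three have been measured in a functional assay for agonist activity at G protein-coupled receptor 88 (Homo sapiens), read by HTRF and cAMP accumulation; on this read-out lower numbers stand for an effect already at smaller amounts and higher numbers for an effect only at larger amounts of compound. Compound 3 stands at the high end of the three numbers: its value is close to that of compound 1, the two lying within the scatter of each other, while compound 2 sits well apart, as the step of a 5.6-fold higher number from compound 2 to compound 3 (0.75 log units; beyond the scatter) shows. Compound 4 `CC[C@H](C)[C@H](N)CN(C(=O)[C@@H]1C[C@H]1c1ccccc1)c1ccc(-c2ccc(OC)cc2)cc1` has not yet been measured. It differs from compound 3 in one place: methoxy in place of trifluoromethyl on an aromatic carbon. Among the compounds with values here, no measured step covers this exact exchange. Within the data shown here, the only step that touches the same position is the one from compound 2 to compound 3, which was modest and beyond the scatter. Compound 1, which carries the same methoxy group but a different side chain, gives 330 nM, a value close to that of compound 3. Compound 4 is therefore expected to land near the values of compound 1 and compound 3, at about 220 nM, with a plausible range from 60 nM to 700 nM, so the expected step of a 1.5-fold lower number from compound 3 to compound 4 (0.19 log units; within the scatter) is small.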

Compound 4, half-maximal effective concentration: 120 nM
Compound 4: the middle estimate sits 1.8-fold (0.26 log units) above what was measured; the measured number falls inside the stated range.
By their numbers in this assay, from the lowest: compounds 2 and 4 (each within the scatter of the next); then compounds 1 and 3 (each within the scatter of the next).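

In this assay, with the sec-butyl side chain held fixed, methoxy in place of trifluoromethyl on this aromatic carbon gives a 2.8-fold lower number from compound 3 to compound 4 (0.45 log units; beyond the scatter), so trifluoromethyl is now set against a second group at this position, not only against propyl. Methoxy and propyl are not separated here, since a 2.0-fold higher number from compound 2 to compound 4 (0.29 log units; within the scatter) stays within the scatter. With methoxy held fixed, the side chain also matters, as sec-butyl in place of isobutyl gives a 2.8-fold lower number from compound 1 to compound 4 (0.44 log units; beyond the scatter) for this pair of compounds.

No measurement given here accounts for these steps. On these data alone, how an ethoxy group, a chlorine atom or a nitrile would fare on this aromatic carbon stays open, as does whether the side-chain step holds with propyl or trifluoromethyl in place of methoxy.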